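From Amino to Nitro on a Shared Core

A few compounds are considered here, and "the series" means these few. Any claim that something is new, unique, unknown or untested is made for them only; others in the source may bear on it.

Measured in a functional assay on A549 cells (Homo sapiens) for antiproliferative activity, read by MTT assay, with a stated time of 48 h; on this read-out lower numbers stand for stronger inhibition and higher numbers for weaker inhibition:
- Compound 1 `COc1cc(C(=O)/C=C/c2c[nH]c3ccccc23)cc([N+](=O)[O-])c1OC`: 1510 nM
- Compound 2 `COc1cc(C(=O)/C=C/c2cn(C)c3ccccc23)cc(SC)c1OC`: 188 nM
- Compound 3 `COc1cc(C(=O)/C=C/c2cn(C)c3ccccc23)cc(N)c1OC`: 498 nM

Compound 3 holds the middle place of these three, with a higher number than compound 2 and a lower number than compound 1. Compound 4 `COc1cc(C(=O)/C=C/c2cn(C)c3ccccc23)cc([N+](=O)[O-])c1OC` has not yet been measured and differs from compound 3 in one place: nitro in place of amino on an aromatic carbon. In words, nitro takes the place of amino on an aromatic carbon, ortho to a methoxy group.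

One measured step involves this same carbon: a 2.6-fold higher number from compound 2 to compound 3 (0.42 log units; beyond the scatter). It shows that a change here can move the number by a modest amount, but it does not involve nitro. Among the compounds with values here, the only measured nitro compound is compound 1 at 1510 nM, and it lacks a methyl group that compound 4 carries. Within the data shown here, no measured pair shows what that methyl group alone does. Compound 1 therefore suggests a higher number, and a step no larger than the measured one is expected. The estimated step is a 1.6-fold higher number from compound 3 to compound 4 (0.21 log units; within the scatter). For compound 4 the expected value is 800 nM, with an estimated range from 250 nM to 2500 nM.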

Compound 4, half-maximal inhibitory concentration: 1060 nM
Beside the measured number, compound 4's estimate is 1.3-fold (0.12 log units) below it, within the range that was stated.
By their numbers in this assay, from the lowest: compound 2; then compound 3; then compounds 4 and 1 (each within the scatter of the next).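

In this assay, nitro on this aromatic carbon, ortho to a methoxy group, gives a 2.1-fold higher number from compound 3 to compound 4 (0.33 log units; beyond the scatter) when it replaces amino and a 5.6-fold higher number from compound 2 to compound 4 (0.75 log units; beyond the scatter) when it replaces methylsulfanyl. With compounds 2, 3 and 4 sharing everything except this one group, the order from the lowest number to the highest is now methylsulfanyl, amino, nitro, and each gap lies beyond the usual scatter, so this carbon tolerates some groups better than others in this small set. The last pair supplies the comparison that was missing for the methyl group: methyl in place of hydrogen on the aromatic nitrogen gives a 1.4-fold lower number from compound 1 to compound 4 (0.15 log units; within the scatter) and so, with nitro on the carbon, leaves the two compounds indistinguishable, though nothing in these data explains the order of the three groups.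

As far as these compounds go, whether that methyl group would matter as little with amino or methylsulfanyl on the carbon remains open. So does the place in this order of other groups at the same carbon, such as a nitrile or a carboxylic acid.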